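The compounds below may be only part of what the source reports. "The series", "measured", "known", "first", "only" and "open" are said of these compounds alone.

Of the compounds shown here, three of one shared core have been measured in a functional assay on K562 cells (Homo sapiens) for antiproliferative activity; on this read-out higher numbers stand for weaker inhibition and lower numbers for stronger inhibition. Compound 1 `Cc1ncn(-c2cc(NC(=O)c3ccc(C)c(Nc4nc(-c5cccnc5)cs4)c3)cc(C(F)(F)F)c2)n1` gives 1630 nM in this assay. Compound 2 `Cc1ccc(C(=O)Nc2cccc(C(F)(F)F)c2)cc1Nc1nc(-c2cccnc2)cs1` gives 1440 nM in this assay. Compound 3 `Cc1cc(NC(=O)c2ccc(C)c(Nc3nc(-c4cccnc4)cs3)c2)cc(-n2cnc(C)c2)c1` gives 3290 nM in this assay, the highest of the three numbers; it sits a 1.1-fold lower number from compound 1 to compound 2 (0.05 log units; within the scatter). Compared with the other two, compound 3 stands beyond the scatter above compound 1, which differs from it in the groups on the amide-bearing ring, and beyond the scatter above compound 2.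

Compound 4 `Cc1cn(-c2cc(NC(=O)c3ccc(C)c(Nc4nc(-c5cccnc5)cs4)c3)cc(C(C)(C)C)c2)cn1` differs from compound 3 in one place: tert-butyl in place of methyl on an aromatic carbon. Going by the values given here, none of the measured steps changes this group, so no step bears on it directly; the only measured single change, a 1.1-fold lower number from compound 1 to compound 2 (0.05 log units; within the scatter), concerns a different group on the same ring and was within the scatter. Compound 1, which carries a trifluoromethyl where compound 3 carries the methyl, lies below compound 3, which suggests that a larger group at this position may go with a somewhat lower number, though this rests on a single pair.

For compound 4 the expected step is therefore a 1.6-fold lower number from compound 3 to compound 4 (0.22 log units; within the scatter), modest and not certain to leave the scatter. Compound 4 is estimated to give 2000 nM in this assay, within a range from 700 nM to 6000 nM.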

Compound 4, half-maximal inhibitory concentration: 640 nM
For compound 4 the middle estimate is 3.1-fold (0.49 log units) above the measured one; measured number outside the range, below it.
By their numbers in this assay, from the lowest: compound 4; then compounds 2 and 1 (each within the scatter of the next); then compound 3.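

In this assay, putting tert-butyl in place of methyl on this aromatic carbon gives a 5.1-fold lower number from compound 3 to compound 4 (0.71 log units; beyond the scatter), so this position responds to what sits on it, and the change here is simply from one carbon to four carbons, with no ring, hydrogen-bond donor, hydrogen-bond acceptor or net charge entering. The only earlier single change, a 1.1-fold lower number from compound 1 to compound 2 (0.05 log units; within the scatter), concerned a different group on the same ring and stayed within the scatter, which makes the step from methyl to tert-butyl the first one shown to leave it. No measurement of any property of these groups is available to explain the step.

With the 4-methyl-1H-imidazol-1-yl group in place, only methyl and tert-butyl are shown at this position, leaving unclear whether the number falls gradually as the group grows, as ethyl or isopropyl could show, or whether the gain belongs to tert-butyl alone. From the compounds shown here alone, it also remains open whether a similarly sized group carrying an amine or an alcohol would keep the lower number.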